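The compounds below may be only part of what the source reports. "The series", "measured", "known", "first", "only" and "open" are said of these compounds alone.

Measured so far in a physicochemical assay for solubility (a lower number here means a less soluble compound, a higher number a more soluble compound), each value being a limit of the assay rather than a number:
- compound 1 `CNC(=O)c1cc(C(=O)NCCCC2CNCCO2)cn(Cc2ccccc2)c1=O`: >= 194 ug/mL
- compound 2 `CNC(=O)c1cc(C(=O)NC2CC2)cn(Cc2ccc3nc[nH]c3c2)c1=O`: >= 163 ug/mL
- compound 3 `CNC(=O)c1cc(C(=O)NC(C)C)cn(Cc2ccccc2)c1=O`: >= 136 ug/mL

Compound 2 stands at a limit, (the limit of >= 163 ug/mL in this assay, at which 1 of the 3 values shown sits), so its solubility is not read as a number. Compound 1 sits at a limit as well, (the limit of >= 194 ug/mL in this assay, at which 1 of the 3 values shown sits). Compound 3 likewise sits at a limit, (the limit of >= 136 ug/mL in this assay, at which 1 of the 3 values shown sits). Going by the values given here, the only step between two compounds that differ in a single place is a step that the two limits leave unreadable from compound 1 to compound 3; both of its ends are limits.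

Compound 4 `CNC(=O)c1cc(C(=O)NC2CC2)cn(Cc2cccc(F)c2)c1=O` differs from compound 2 in one place: 3-fluorophenyl in place of 1H-benzimidazol-6-yl on a saturated chain carbon bound to an aromatic nitrogen. Among the compounds with values here, no measured step bears on this change: none of the three compounds varies the group on the saturated chain carbon bound to the aromatic nitrogen, and the one step that exists cannot be sized. The measured values give no direction to expect beyond the scatter. Compound 4 is therefore estimated at 150 ug/mL, within 50 ug/mL to 300 ug/mL. The expected step of an at least 1.0-fold lower number from compound 2 to compound 4 (0.03 log units; that floor lies within the scatter) is meant to lie within the scatter.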

Compound 4, solubility: >= 133 ug/mL
Compound 4: a limit, no number; the forecaster's own chance of this, stated with the estimate: 50%; the middle value is on the limit's open side.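

In this assay compound 4 gives >= 133 ug/mL, which is a limit of the assay and not a number. Going by these compounds alone, compound 2 also stands at a limit, so no step from it can be read. The compounds shown leave open whether 3-fluorophenyl in place of 1H-benzimidazol-6-yl changes the read-out in this assay at all.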